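Hydrazone aryl variation in a diaryl ether urea series

The compounds below may be only part of what the source reports. "The series", "measured", "known", "first", "only" and "open" are said of these compounds alone.

Measured values in a functional assay on HT-29 cells (Homo sapiens) for cytotoxicity, read by MTT assay, with a stated time of 72 h; on this read-out lower numbers stand for stronger inhibition and higher numbers for weaker inhibition:
compound 1, `CN(C)CCn1cnnc1-c1cc(Oc2ccc(NC(=O)N/N=C/c3ccc(O)c(Br)c3)cc2F)ccn1`: 450 nM
compound 2, `CN(C)CCn1cnnc1-c1cc(Oc2ccc(NC(=O)N/N=C/c3c[nH]c4ccccc34)cc2F)ccn1`: 1300 nM
compound 3, `Cc1cc(/C=N/NC(=O)Nc2ccc(Oc3ccnc(-c4nncn4CCN(C)C)c3)c(F)c2)cc(C)c1O`: 1220 nM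

Compound 3 stands second highest of the three numbers; a 1.1-fold lower number from compound 2 to compound 3 (0.03 log units; within the scatter) is within the scatter, while a 2.7-fold higher number from compound 1 to compound 3 (0.43 log units; beyond the scatter) lies beyond it. Compound 4, `CN(C)CCn1cnnc1-c1cc(Oc2ccc(NC(=O)N/N=C/c3ccc(O)cc3O)cc2F)ccn1`, carries 2,4-dihydroxyphenyl in place of 4-hydroxy-3,5-dimethylphenyl on a carbon with a double bond to nitrogen. Among the measured compounds shown here, no measured step exchanges one hydroxyphenyl pattern for another. The steps that touch this position, a 2.9-fold higher number from compound 1 to compound 2 (0.46 log units; beyond the scatter) and a 2.7-fold higher number from compound 1 to compound 3 (0.43 log units; beyond the scatter), are both modest, and a 1.1-fold lower number from compound 2 to compound 3 (0.03 log units; within the scatter) is flat, so changes here shift this assay only moderately. A step of a 1.4-fold lower number from compound 3 to compound 4 (0.13 log units; within the scatter) is expected, which stays within the scatter. Compound 4 is therefore estimated at 900 nM, with a range from 350 nM to 2500 nM.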

Compound 4, half-maximal inhibitory concentration: 52600 nM
For compound 4 the middle estimate is 58-fold (1.77 log units) below the measured one, and the stated range ends below it.
By their numbers in this assay, from the lowest: compound 1; then compounds 3 and 2 (each within the scatter of the next); then compound 4.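

In this assay, a 43-fold higher number from compound 3 to compound 4 (1.63 log units; beyond the scatter) and a 40-fold higher number from compound 2 to compound 4 (1.61 log units; beyond the scatter) and a 120-fold higher number from compound 1 to compound 4 (2.07 log units; beyond the scatter) are all large steps, so this position is far less tolerant than the modest or flat steps among compounds 1, 2 and 3 suggested. Compounds 1, 3 and 4 all carry a 4-hydroxy group, so that group alone does not preserve the lower numbers. No evidence at hand accounts for the loss.

As far as these compounds go, whether the loss follows the added 2-hydroxy group or the absence of the other substituents remains open. A plain 4-hydroxyphenyl or a 2-methoxy-4-hydroxyphenyl on this carbon would separate the two.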